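The source may hold more compounds than are shown below. What is called first, only, known or untested is meant among the compounds shown, and "the series" means these compounds.

Measured so far:
compound 1 `O=C(Nc1cccc(-n2cc(-c3ccncc3)c(-c3ccc(Cl)c(O)c3)n2)c1)Nc1ccc(Cl)c(Cl)c1` — > 32500 nM
compound 2 `COc1cc(-c2nn(-c3cccc(NC(=O)c4ccc(Cl)c(C(F)(F)F)c4)c3)cc2-c2ccncc2)ccc1Cl` — > 32500 nM
compound 3 `O=C(Nc1cccc(-n2cc(-c3ccncc3)c(-c3ccc(Cl)c(O)c3)n2)c1)Nc1cc(C(F)(F)F)cc(C(F)(F)F)c1` — 18000 nM

The three values above come from a functional assay on 786-0 cells (Homo sapiens) for inhibition, read by sulforhodamine B assay, with a stated time of 48 h; on this read-out higher numbers stand for lower toxicity in this test and lower numbers for higher toxicity in this test. For compound 1 the result is only a limit, > 32500 nM, not a number. Compound 2 likewise reaches only a limit, > 32500 nM. For the measured compounds named here, compound 3 gives 18000 nM, the one numerical reading. Going by the values given here, compound 2 therefore stands where most of these results sit (the limit of > 32500 nM in this assay, at which 2 of the 3 values shown sit); nothing separates it from compound 1, and no single-point step between any two of the measured compounds is available.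

Compound 4 `COc1cc(-c2nn(-c3cccc(NC(=O)Nc4cccc(C(F)(F)F)c4)c3)cc2-c2ccncc2)ccc1Cl` is the compound not yet measured in this assay. It is reached from compound 2 by one change ((3-(trifluoromethyl)phenyl)amino in place of 4-chloro-3-(trifluoromethyl)phenyl on a carbonyl carbon). The change turns the amide linker of compound 2 into a urea of the kind carried by compound 1 and compound 3, while the remaining part of compound 2 is kept.

Given that compound 2 sits at the limit > 32500 nM and that compound 1, the closest urea, also reaches only its limit > 32500 nM, compound 4 is expected to stay at or near the same level, with a step of an at least 1.0-fold lower number from compound 2 to compound 4 (0.03 log units; that floor lies within the scatter) not beyond the usual scatter. Compound 4 is therefore estimated at 30000 nM, within 12000 nM to 80000 nM.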

Compound 4, concentration lethal to 50% of the cells: > 50000 nM
Compound 4 gave a limit, no number; the forecaster's own chance of this, stated with the estimate: 55%; at least 1.6-fold (0.22 log units) between middle value and limit.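

In this assay, compound 2 and compound 4 both end at limits rather than numbers, so no step can be read between them. The compounds shown leave open whether (3-(trifluoromethyl)phenyl)amino in place of 4-chloro-3-(trifluoromethyl)phenyl on a carbonyl carbon changes the reading at all.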